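Swapping the Aryl Ring on a Shared Core

A few compounds are considered here, and "the series" means these few. Any claim that something is new, unique, unknown or untested is made for them only; others in the source may bear on it.

Compound 1 `C=CCOc1cc(OC)c(C(=O)/C=C/Cc2ccccc2)c(OCC=C)c1`, compound 2 `C=CCOc1cc(OC)c(C(=O)/C=C/c2ccncc2)c(OCC=C)c1` and compound 3 `C=CCOc1cc(OC)c(C(=O)/C=C/c2ccccc2F)c(OCC=C)c1` share one core and differ only in the group on a double-bonded chain carbon bound to a double-bonded chain carbon. In a toxicity assay on cells (Macrophage, Mus musculus, strain BALB/c) for cytotoxicity, read by MTT assay (on this read-out lower numbers stand for stronger inhibition and higher numbers for weaker inhibition), compound 1 gives 14800 nM, compound 2 gives "not determined" (no result reported), and compound 3 gives 13300 nM. Among the measured compounds shown here, the only completed step, a 1.1-fold lower number from compound 1 to compound 3 (0.05 log units; within the scatter), shows that exchanging this group barely moved the number, so compound 3 and compound 1 sit within the scatter of each other, while compound 2 adds no number. Compound 4 `C=CCOc1cc(OC)c(C(=O)/C=C/c2ccc(Cl)cc2)c(OCC=C)c1` carries 4-chlorophenyl in place of 2-fluorophenyl on a double-bonded chain carbon bound to a double-bonded chain carbon. Because a 1.1-fold lower number from compound 1 to compound 3 (0.05 log units; within the scatter) left the read-out essentially unchanged, the step expected here, a 1.1-fold higher number from compound 3 to compound 4 (0.02 log units; within the scatter), is none beyond the scatter. Compound 4 is therefore estimated at 14000 nM, within 6500 nM to 30000 nM.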

Compound 4, half-maximal inhibitory concentration: 13000 nM
Estimate against measurement, compound 4: 1.1-fold (0.03 log units) above; low and high end bracket the measured number.
By their numbers in this assay, from the lowest: compounds 4, 3 and 1 (each within the scatter of the next).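

In this assay, the exchange of 2-fluorophenyl for 4-chlorophenyl gives a 1.0-fold lower number from compound 3 to compound 4 (0.01 log units; within the scatter) and the exchange of benzyl for 4-chlorophenyl gives a 1.1-fold lower number from compound 1 to compound 4 (0.06 log units; within the scatter) at this same position on the double-bonded chain carbon. With a chlorine-bearing ring now tested as well, all three groups with a measured number give values within the scatter of one another, so this position has not yet shown a clear response to any exchange. No supporting measurement is available to explain this flat result. Still open, going by these compounds, is whether an amine or a carboxylic acid on this carbon would move the number beyond the scatter.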